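Swapping 3-hydroxyphenyl for 4-vinylphenyl on a sulfonyl sulfur

The source may report more compounds than this note shows. Statements on the series, on what has been measured and on what is new or still open speak of the compounds shown alone.

In an ADME assay on HEK293 cells (Homo sapiens) for cytotoxicity, read by resazurin assay, with a stated time of 48 h (on this read-out lower numbers stand for higher toxicity in this test and higher numbers for lower toxicity in this test), compound 1 `O=S(=O)(Nc1ccc(-c2nc3ccccc3o2)cc1)c1cccc(O)c1` gives > 100000 nM. That figure for compound 1 is a limit of the assay and not a number. Compound 1 thus stands at the limit of > 100000 nM in this assay, at which 1 of the 3 values shown sits. Two other sulfonamides do give numbers: compound 2 `COc1cccc(S(=O)(=O)Nc2ccc3oc(-c4ccccc4)nc3c2)c1` reads 63000 nM and compound 3 `O=S(=O)(Nc1ccc2oc(-c3ccccc3)nc2c1)c1ccc(Cl)c(C(F)(F)F)c1` reads 66000 nM, and these two values lie within the usual scatter of each other.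

Compound 4 `C=Cc1ccc(S(=O)(=O)Nc2ccc(-c3nc4ccccc4o3)cc2)cc1` keeps the core of compound 1 and carries 4-vinylphenyl in place of 3-hydroxyphenyl on a sulfonyl sulfur. Among the compounds with values here, no measured pair differs in only one place, so nothing yet gauges this change directly. Within the data shown here, the only numbers at hand are those of compound 2 and compound 3, and a modest move toward them is expected. The estimated step of an at least 1.4-fold lower number from compound 1 to compound 4 (0.15 log units; that floor lies within the scatter) in this assay is small and points toward higher toxicity, though another limit would be no surprise. For compound 4 the expected value is 70000 nM, with an estimated range from 30000 nM to 150000 nM.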

Compound 4, half-maximal cytotoxic concentration: > 100000 nM
Compound 4: only a limit was reported (the forecaster's own chance of this, stated with the estimate: 40%); middle value at least 1.4-fold (0.15 log units) away from the limit.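

In this assay compound 4 gives > 100000 nM, which is a limit of the assay and not a number. Compound 1 also stands at a limit, so no step between compound 1 and compound 4 can be read: the limit of > 100000 nM in this assay, at which 2 of the 4 values shown sit.

The compounds shown leave open whether 4-vinylphenyl in place of 3-hydroxyphenyl on a sulfonyl sulfur shifts the read-out at all.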